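From a thioether chain to a furan ring

A few compounds are considered here, and "the series" means these few. Any claim that something is new, unique, unknown or untested is made for them only; others in the source may bear on it.

Measured in an ADME assay on MDBK cells (Bos taurus) for cytotoxicity, read by MTT assay, with a stated time of 96 h; on this read-out higher numbers stand for lower toxicity in this test and lower numbers for higher toxicity in this test:
Compound 1 `FC(F)(F)c1cccc(NC(=S)Nc2ccc(I)cc2)c1`: 9500 nM
Compound 2 `CSCCCNC(=S)Nc1cccc(C(F)(F)F)c1`: > 100000 nM

Compound 2 stands at the limit of > 100000 nM in this assay, at which 1 of the 2 values shown sits, so it is a limit and not an exact number. Compound 3 `FC(F)(F)c1cccc(NC(=S)NCc2ccco2)c1` differs from it in one place: furan-2-yl in place of 2-(methylsulfanyl)ethyl on a saturated chain carbon bound to an amide-type nitrogen. In short, furan-2-yl replaces 2-(methylsulfanyl)ethyl on a saturated chain carbon bound to an amide-type nitrogen. Going by the values given here, only one measured step bears on this, the large at least 10-fold higher number from compound 1 to compound 2 (1.02 log units; beyond the scatter), which lies beyond the scatter. Compound 1 has an aromatic ring in that place and compound 3 regains one, so a smaller move towards lower numbers is expected. The expected step is an at least 1.6-fold lower number from compound 2 to compound 3 (0.22 log units; that floor lies within the scatter). For compound 3 the estimated value is 60000 nM, with an expected range of 20000 nM to 100000 nM.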

Compound 3, half-maximal cytotoxic concentration: > 100000 nM
Compound 3: a limit, no number (the forecaster's own chance of this, stated with the estimate: 40%); at least 1.6-fold (0.22 log units) between middle value and limit.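

In this assay compound 3 gives > 100000 nM, which is a limit and not a number. Placing (furan-2-yl)methyl where compound 1 has 4-iodophenyl gives an at least 10-fold higher number from compound 1 to compound 3 (1.02 log units; beyond the scatter), so an aromatic ring carried on a saturated chain carbon does not restore the lower number of compound 1, and the step from compound 2 to compound 3 cannot be read: the limit of > 100000 nM in this assay, at which 2 of the 3 values shown sit.

On these data alone, whether a phenyl ring or a dimethylamino group on that chain carbon would give a measurable number stays open. So does whether the ring or the iodine of 4-iodophenyl matters more for the number of compound 1.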